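The compounds below may be only part of what the source reports. "The series", "measured", "known", "first", "only" and "open" are said of these compounds alone.

In a functional assay on HL-60 cells (Homo sapiens) for antiproliferative activity, read by XTT assay, with a stated time of 72 h (on this read-out higher numbers stand for weaker inhibition and lower numbers for stronger inhibition), compound 1 `CSc1ncnc2c1c(-c1cccs1)cn2[C@@H]1O[C@H](CO)[C@@H](O)[C@H]1O` gives 1130 nM and compound 2 `C#Cc1cn([C@@H]2O[C@H](CO)[C@@H](O)[C@H]2O)c2ncnc(SC)c12` gives 50 nM. Compound 3 `CNc1ncnc2c1c(-c1ccco1)cn2[C@@H]1O[C@H](CO)[C@@H](O)[C@H]1O` gives 620 nM, a value within the usual scatter of compound 1 and well above that of compound 2. Compound 4 `CNc1ncnc2c1c(-c1cc3ccccc3o1)cn2[C@@H]1O[C@H](CO)[C@@H](O)[C@H]1O` differs from compound 3 by a single change: 1-benzofuran-2-yl in place of furan-2-yl on an aromatic carbon. Among the measured compounds shown here, the only measured step bearing on this is a 23-fold lower number from compound 1 to compound 2 (1.35 log units; beyond the scatter), where ethynyl replaced thiophen-2-yl on the same aromatic carbon, so the smaller group went with the lower number. That pair differs from compound 3 elsewhere too, making it a rough guide, but a moderate rise in this assay is expected with the larger 1-benzofuran-2-yl. The expected step is a 3.2-fold higher number from compound 3 to compound 4 (0.51 log units; beyond the scatter). For compound 4 the estimated value is 2000 nM, with an expected range of 400 nM to 10000 nM.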

Compound 4, half-maximal inhibitory concentration: 8950 nM
The estimate for compound 4 lay 4.5-fold (0.65 log units) below the measured number; measured number inside the range.
By their numbers in this assay, from the lowest: compound 2; then compounds 3 and 1 (each within the scatter of the next); then compound 4.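

Replacing furan-2-yl with 1-benzofuran-2-yl on this aromatic carbon gives a 14-fold higher number from compound 3 to compound 4 (1.16 log units; beyond the scatter) in this assay. The five-membered aromatic ring with its oxygen stays in place, so adding the six-membered aromatic ring of carbon only is enough to produce a large step at this position. Nothing measured here gives a cause for this step. Going by these compounds, it remains open whether ethynyl on the core of compound 3 would also give a low number. How a smaller chain such as ethyl, or an amine, would behave at this carbon is also unknown.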